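Amide aryl change from methylphenyl to fluorodimethylphenyl

This account rests on a few compounds, and the source may have more. Where it says the series, first, only, none or still open, it means among the compounds named here.

Compound 1 `CCOc1ccc2nc(C)cc(OCC(=O)Nc3cc(C)cc(C)c3)c2c1`: in a toxicity assay on HepG2 cells (Homo sapiens) for inhibition, read by CellTiter-Glo, with a stated time of 48 h (a higher number here means a weaker inhibitor, a lower number a stronger inhibitor), compound 1 returns only an assay limit, > 100000 nM.
Compound 2 `CCCc1cc(OCC(=O)Nc2cc(C)cc(C)c2)c2cc(OC)ccc2n1`: in this assay compound 2 gives 12600 nM.
Compound 3 `COc1ccc2nc(C)cc(OCC(=O)Nc3cccc(C)c3)c2c1`: in this assay compound 3 gives 39800 nM.

Among the two numbered results, compound 3 stands highest, and compound 2 sits beyond the usual scatter below it. Compound 1 contributes a limit rather than a number (the limit of > 100000 nM in this assay, at which 1 of the 3 values shown sits).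

Compound 4 `COc1ccc2nc(C)cc(OCC(=O)Nc3cc(C)c(F)c(C)c3)c2c1` differs from compound 3 in one place: 4-fluoro-3,5-dimethylphenyl in place of 3-methylphenyl on an amide-type nitrogen. Among the compounds with values here, no measured pair isolates this change, so the expected step of a 1.0-fold higher number from compound 3 to compound 4 (0.00 log units; within the scatter) is taken as none beyond the scatter in this assay, with a wide range. Compound 4 is therefore estimated at 40000 nM, between 12000 nM and 150000 nM.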

Compound 4, half-maximal inhibitory concentration: > 100000 nM
Compound 4 ended at the assay's limit (the forecaster's own chance of this, stated with the estimate: 25%); at least 2.5-fold (0.39 log units) between middle value and limit.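

Within the data shown here, on the amide-type nitrogen, 4-fluoro-3,5-dimethylphenyl in place of 3-methylphenyl gives an at least 2.5-fold higher number from compound 3 to compound 4 (0.40 log units; beyond the scatter) in this assay, the first one-place change here, so this aryl group does affect the read-out, with weaker inhibition. In this assay compound 4 gives > 100000 nM, which is a limit and not a number. The step therefore has only a lower bound, and the limit now recurs: the limit of > 100000 nM in this assay, at which 2 of the 4 values shown sit.

On these data alone, the change brings in fluorine and a further methyl together, so which of them carries the step stays open. As far as these compounds go, how an amine or a carboxylic acid on this phenyl ring would read also stays open.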